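A chlorophenyl swap on the road to compound 3

A few compounds are considered here, and "the series" means these few. Any claim that something is new, unique, unknown or untested is made for them only; others in the source may bear on it.

- Compound 1 `CC1(C)O[C@H]2O[C@H](Cn3cc(CN4C(=O)C(=O)c5ccccc54)nn3)[C@H](O)[C@H]2O1` with > 200000 nM as a limit
- Compound 2 `COc1ccc(N/N=C2\C(=O)N(Cc3cn(C[C@H]4O[C@@H]5OC(C)(C)O[C@@H]5[C@H]4O)nn3)c3ccccc32)cc1` with 74500 nM as a number

Among the compounds with values here, in an ADME assay on Vero cells (Chlorocebus sabaeus) for cytotoxicity, read by fluorescence and resazurin assay, with a stated time of 3 days (on this read-out lower numbers stand for higher toxicity in this test and higher numbers for lower toxicity in this test), compound 2 gives 74500 nM as the only actual number on hand. Compound 1 gives > 200000 nM, which is a limit and not a number. Within the data shown here, with one number and one limit, the series offers no measured step between compounds.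

Compound 3 `CC1(C)O[C@H]2O[C@H](Cn3cc(CN4C(=O)/C(=N\Nc5cccc(Cl)c5)c5ccccc54)nn3)[C@H](O)[C@H]2O1` has not yet been measured in this assay. Compared with compound 2, it carries 3-chlorophenyl in place of 4-methoxyphenyl on an amine nitrogen, and the rest of the structure is shared. Among the measured compounds shown here, no measured pair shows what a change of this kind does, so any forecast is tentative. The expectation rests on compound 2 at 74500 nM, the measured compound that shares the most with compound 3. The expected change is a 1.1-fold lower number from compound 2 to compound 3 (0.03 log units; within the scatter), which would stay within the usual scatter, with neither direction favoured. In this assay compound 3 is estimated at 70000 nM, within an expected range of 25000 nM to 200000 nM.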

Compound 3, half-maximal cytotoxic concentration: 70000 nM
Compound 3: the middle estimate sits on the measured number at the digits printed; the range from low to high includes it.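

In this assay, the series now has its first measured step at the amine nitrogen whose other neighbour is a double-bonded nitrogen. Placing 3-chlorophenyl there in place of 4-methoxyphenyl gives a 1.1-fold lower number from compound 2 to compound 3 (0.03 log units; within the scatter), so two aryl groups that differ in their substituent, in their heavy atoms and in their count of hydrogen-bond acceptors give values within the scatter of each other, and this single pair gives no sign that the read-out depends on which of the two groups is present. Compound 1 remains the one entry held at a limit and not a number, so no step to it can be read: the limit of > 200000 nM in this assay, at which 1 of the 3 values shown sits.

One pair cannot separate the part played by the chlorine from that of the methoxy group, or show whether the result would hold for either group in another ring position. It also leaves open whether a plain phenyl, a pyridine ring, an aryl group bearing an amine or a carboxylic acid, or a longer chain on this nitrogen would stay within the scatter of these values or move beyond it.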